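Nitro in place of methoxy: what to expect

The compounds below may be only part of what the source reports. "The series", "measured", "known", "first", "only" and "open" are said of these compounds alone.

Measured in a functional assay on Jurkat cells (Homo sapiens) for cytotoxicity, read by MTT assay, with a stated time of 24 h; on this read-out lower numbers stand for stronger inhibition and higher numbers for weaker inhibition
compound 1 `O=C(/C=C/c1ccc(NC(=O)Nc2ccccc2)cc1)NO` gives 2700 nM
compound 2 `COc1ccc(NC(=O)Nc2ccc(/C=C/C(=O)NO)cc2)cc1` gives 1800 nM

Compound 2 stands level with compound 1 within the scatter. For the measured compounds named here, the only measured step is a 1.5-fold lower number from compound 1 to compound 2 (0.18 log units; within the scatter), with methoxy in place of hydrogen on an aromatic carbon, so the two compounds cannot be ranked.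

The next compound, compound 3 `O=C(/C=C/c1ccc(NC(=O)Nc2ccc([N+](=O)[O-])cc2)cc1)NO`, has not yet been measured. It differs from compound 2 by nitro in place of methoxy on an aromatic carbon, which is nitro in place of methoxy on an aromatic carbon, para to a large group. The measured step bears on this change only in part. It concerns the methoxy that leaves here, and it shows that the presence of methoxy made no difference beyond the scatter. Going by the values given here, no measured compound carries nitro, so its own contribution is unknown, and the range has to stay wide. With only a 1.5-fold lower number from compound 1 to compound 2 (0.18 log units; within the scatter) as a guide, no step beyond the scatter is expected in this assay, and no direction can be firmly expected.

The estimate amounts to a 1.3-fold higher number from compound 2 to compound 3 (0.12 log units; within the scatter), an expected step that remains small. For compound 3 the estimated value is 2400 nM, with an expected range from 900 nM to 6000 nM.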

Compound 3, half-maximal inhibitory concentration: 2700 nM
Estimate against measurement, compound 3: 1.1-fold (0.05 log units) below; measured number inside the range.
By their numbers in this assay, from the lowest: compounds 2, 1 and 3 (each within the scatter of the next).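

In this assay, nitro in place of methoxy on an aromatic carbon, para to a large group, gives a 1.5-fold higher number from compound 2 to compound 3 (0.18 log units; within the scatter) and nitro in place of hydrogen gives no change at the digits printed from compound 1 to compound 3 (within the scatter) in the same assay. This is the first look at nitro here, and it shows that hydrogen, methoxy and nitro at this one place all stay within the scatter of each other, so compounds 1, 2 and 3 cannot be ranked by this substituent and this position has so far shown no sensitivity to the exchanges tried. No further measurement is available that could explain why these three compounds stand level.

The compounds shown leave open whether an amine or a carboxylic acid on this aromatic carbon would move the number beyond the scatter, as none of the three groups seen so far does. They also leave open whether a longer chain there would behave the same way, and whether changes to the shared core, which all three compounds keep, would matter more in this assay than any exchange at this place.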